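Dropping the chloro from compound 1: working notes

The source may report more compounds than this note shows. Statements on the series, on what has been measured and on what is new or still open speak of the compounds shown alone.

In an ADME assay on HEK293 cells (Homo sapiens) for cytotoxicity, read by resazurin assay, with a stated time of 48 h (on this read-out lower numbers stand for higher toxicity in this test and higher numbers for lower toxicity in this test), compound 1 (`O=S(=O)(Nc1ccc(-c2nc3ccccc3o2)cc1)c1ccc(Cl)c(C(F)(F)F)c1`) gives 69000 nM, compound 2 (`COc1cccc(S(=O)(=O)Nc2ccc3oc(-c4ccccc4)nc3c2)c1`) gives 63000 nM and compound 3 (`O=[N+]([O-])c1cc(S(=O)(=O)Nc2ccc(-c3nc4ccccc4o3)cc2)ccc1Cl`) gives 85000 nM. Going by the values given here, these three values lie within the scatter of one another, so compound 1 stands level with the other two and no compound is separated on these numbers.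

Compound 4 (`O=S(=O)(Nc1ccc(-c2nc3ccccc3o2)cc1)c1cccc(C(F)(F)F)c1`) is compound 1 with hydrogen in place of chloro on an aromatic carbon, ortho to a trifluoromethyl group and para to a large group (hydrogen in place of chloro on an aromatic carbon).

Among the compounds with values here, only one measured step bears on this change: a 1.2-fold higher number from compound 1 to compound 3 (0.09 log units; within the scatter). That step lies within the scatter, but it keeps the chloro and replaces the trifluoromethyl group, so it is indirect evidence. Within the data shown here, no measured pair shows the loss of chloro itself. Compound 2 differs from compound 1 in more than one place, and only its value can be set beside that of compound 1.

With so little evidence, no step beyond the scatter is expected in this assay, and no direction is favoured. The estimated step is a 1.0-fold higher number from compound 1 to compound 4 (0.01 log units; within the scatter). For compound 4 the expected value is 70000 nM, with an estimated range from 40000 nM to 120000 nM.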

Compound 4, half-maximal cytotoxic concentration: > 100000 nM
Compound 4 was reported as a limit; the forecaster's own chance of this, stated with the estimate: 15%; at least 1.4-fold (0.15 log units) between middle value and limit.
By their numbers in this assay, from the lowest: compounds 2, 1 and 3 (each within the scatter of the next). At a limit, above all of these: compound 4.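

In this assay compound 4 is reported only as a limit, > 100000 nM. The loss of the chloro from the aromatic carbon ortho to a trifluoromethyl group can now be read directly, which the earlier step could not show because it kept the chloro, and the change gives an at least 1.4-fold higher number from compound 1 to compound 4 (0.16 log units; that floor lies within the scatter). Hydrogen at this position therefore gives no sign of a lower number on this read-out, but whether the true step lies beyond the scatter cannot be told from a floor alone: the limit of > 100000 nM in this assay, at which 1 of the 4 values shown sits.

The compounds shown leave open whether removing the chloro has the same outcome with nitro in place of trifluoromethyl, as in compound 3, and whether the trifluoromethyl group itself can be replaced by hydrogen. They also leave open how an amine or a carboxylic acid at the chloro position would read in this assay, so the result for hydrogen cannot yet be extended to other groups at this place.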